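Swapping the Aromatic Cap: From Compound 3 to Compound 4

The source may hold more compounds than are shown below. What is called first, only, known or untested is meant among the compounds shown, and "the series" means these compounds.

Measured so far, in a functional assay on NFF cells (Homo sapiens) for antiproliferative activity; a lower number here means a stronger inhibitor, a higher number a weaker inhibitor:
- compound 1 `O=C(CCCCC[C@H](NC(=O)c1cc2ccccc2[nH]1)C(=O)NCc1ccccc1)NO` gives 1260 nM
- compound 2 `O=C(/C=C/c1ccccc1)N[C@@H](CCCCCC(=O)NO)C(=O)NCc1ccccc1` gives 4010 nM
- compound 3 `O=C(CCCCC[C@H](NC(=O)c1cccs1)C(=O)NCc1ccccc1)NO` gives 5200 nM

Compound 3 carries the highest of the three numbers. Its nearest neighbour is compound 2, within the scatter, while compound 1 lies furthest away: a 4.1-fold higher number from compound 1 to compound 3 (0.62 log units; beyond the scatter). Compound 4 `O=C(CCCCC[C@H](NC(=O)c1ccc(C(F)(F)F)cc1)C(=O)NCc1ccccc1)NO` differs from compound 3 only at the cap: 4-(trifluoromethyl)phenyl in place of thiophen-2-yl on a carbonyl carbon.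

Among the compounds with values here, two measured steps bear on this change, since both also exchange the group on that carbonyl carbon. One is large enough to count, a 4.1-fold higher number from compound 1 to compound 3 (0.62 log units; beyond the scatter), the other is not, a 1.3-fold higher number from compound 2 to compound 3 (0.11 log units; within the scatter). Together they show that the cap moves the number by modest amounts at most, and none of the three caps resembles a trifluoromethyl-bearing phenyl closely. Compound 4 is therefore expected to stay within the scatter in either direction, and the estimated step is a 1.3-fold lower number from compound 3 to compound 4 (0.11 log units; within the scatter). Compound 4 is estimated at 4000 nM, with a range from 1500 nM to 12000 nM.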

Compound 4, half-maximal inhibitory concentration: 1610 nM
Estimate against measurement, compound 4: 2.5-fold (0.40 log units) above, within the range that was stated.
By their numbers in this assay, from the lowest: compounds 1 and 4 (each within the scatter of the next); then compounds 2 and 3 (each within the scatter of the next).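

In this assay, the exchange on this carbonyl carbon now gives two further steps beyond the scatter (a 3.2-fold lower number from compound 3 to compound 4 (0.51 log units; beyond the scatter)) and (a 2.5-fold lower number from compound 2 to compound 4 (0.40 log units; beyond the scatter)), so 4-(trifluoromethyl)phenyl separates from both thiophen-2-yl and 2-phenylethenyl. The remaining step is within the scatter (a 1.3-fold higher number from compound 1 to compound 4 (0.11 log units; within the scatter)), so 1H-indol-2-yl is no longer the only cap in the lower pair of numbers, and a six-membered aromatic ring of carbon only serves here as well. Nothing measured here accounts for the difference between these caps.

The compounds shown leave open whether the trifluoromethyl group or the phenyl ring carries the step, since a plain phenyl or a 4-chlorophenyl cap does not stand among them. Going by these compounds, how a cap bearing an amine or a carboxylic acid would behave also remains open.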